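The compounds below may be only part of what the source reports. "The series", "measured", "known", "first", "only" and "open" are said of these compounds alone.

Compound 3 `COc1cc2c(Oc3ccc(NC(=O)c4nn(-c5ccc(F)cc5)c(=O)c5ccccc45)cc3F)ccnc2cc1OCCCN1CCC(C)CC1` gives 110 nM in a functional assay on NCI-H460 cells (Homo sapiens) for cytotoxicity, read by MTT assay, with a stated time of 72 h (on this read-out lower numbers stand for stronger inhibition and higher numbers for weaker inhibition), the lowest of the three numbers seen so far. Compound 1 `COc1cc2c(Oc3ccc(NC(=O)c4nn(-c5cccc(F)c5)c(=O)c5ccccc45)cc3F)ccnc2cc1OCCCN1CCCC1` gives 190 nM, within the scatter of compound 3. Going by the values given here, compound 2 `COc1cc2c(Oc3ccc(NC(=O)c4nn(-c5ccccc5)c(=O)c5ccccc45)cc3F)ccnc2cc1OCCCN1CCC(C)CC1` gives 550 nM, and the step of a 5.0-fold lower number from compound 2 to compound 3 (0.70 log units; beyond the scatter) is the only single-place step measured. Compound 4 `COc1cc2c(Oc3ccc(NC(=O)c4nn(-c5cccc(F)c5)c(=O)c5ccccc45)cc3F)ccnc2cc1OCCCN1CCC(C)CC1` carries the change (3-fluorophenyl in place of 4-fluorophenyl on an aromatic nitrogen). Among the compounds with values here, no measured step isolates this change; compounds 1 and 3 differ in the fluorine position and also in the amine tail, and their values lie within the scatter of each other. Compound 4 is therefore expected near compound 3, with a 1.4-fold higher number from compound 3 to compound 4 (0.13 log units; within the scatter) and no step beyond the scatter; the estimate for compound 4 is 150 nM, in a range from 60 nM to 400 nM.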

Compound 4, half-maximal inhibitory concentration: 190 nM
The estimate for compound 4 lay 1.3-fold (0.10 log units) below the measured number; the range from low to high includes it.
By their numbers in this assay, from the lowest: compounds 3, 1 and 4 (each within the scatter of the next); then compound 2.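

In this assay, 3-fluorophenyl in place of 4-fluorophenyl on the aromatic nitrogen gives a 1.7-fold higher number from compound 3 to compound 4 (0.24 log units; within the scatter) and so does not separate the two fluorine placements. Both placements stand apart from the phenyl of compound 2, with a 2.9-fold lower number from compound 2 to compound 4 (0.46 log units; beyond the scatter) alongside a 5.0-fold lower number from compound 2 to compound 3 (0.70 log units; beyond the scatter) for the earlier step. With 3-fluorophenyl held constant, the tail exchange gives no change at the digits printed from compound 1 to compound 4 (within the scatter) and so does not separate 4-methylpiperidin-1-yl from pyrrolidin-1-yl. No measurement at hand accounts for these steps. Open, as far as these compounds go, is whether chlorine or methoxy in place of the fluorine, or morpholine on the chain, would hold these numbers.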